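This account rests on a few compounds, and the source may have more. Where it says the series, first, only, none or still open, it means among the compounds named here.

Three selenium-bearing carbamates have been measured in a functional assay on PC-3 cells (Homo sapiens) for cytotoxicity, read by MTT assay, with a stated time of 72 h; on this read-out lower numbers stand for stronger inhibition of growth and higher numbers for weaker inhibition of growth. Compound 1 `CC(C)COC(=O)Nc1ccc([Se][Se]c2ccc(NC(=O)OCC(C)C)cc2)cc1` gives 48900 nM, compound 3 `CCOC(=O)Nc1ccc([Se][Se]c2ccc(NC(=O)OCC)cc2)cc1` gives 52200 nM, and compound 2 `CCCCOC(=O)Nc1ccc([Se]C#N)cc1` gives 40800 nM. Compound 2 holds the lowest of the three numbers, yet its differences to compound 1 and to compound 3 fall within the scatter, so no order can be read among them. Compound 4 `CCCCCCOC(=O)Nc1ccc([Se]C#N)cc1` is not yet measured; it differs from compound 2 by ethyl in place of hydrogen on a saturated chain carbon, four bonds along the chain from an oxygen next to a carbonyl group. Nothing measured here shows how lengthening this saturated chain acts, and compound 1 and compound 3, which also differ in their saturated chain, show two values within the scatter of each other. A step from compound 2 to compound 4 no larger than the scatter is therefore expected, in no set direction, namely a 1.2-fold lower number from compound 2 to compound 4 (0.07 log units; within the scatter). Compound 4 is estimated at 35000 nM, within 15000 nM to 80000 nM.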

Compound 4, concentration for total growth inhibition: 44600 nM
Estimate against measurement, compound 4: 1.3-fold (0.11 log units) below; the measured number falls inside the stated range.
By their numbers in this assay, from the lowest: compounds 2, 4, 1 and 3 (each within the scatter of the next).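

In this assay, the step from hydrogen to ethyl on a saturated chain carbon, four bonds along the chain from an oxygen next to a carbonyl group, is now measured directly as a 1.1-fold higher number from compound 2 to compound 4 (0.04 log units; within the scatter). For the compounds shown here, this gives the first single-place comparison, and it shows that this extension of the chain, on the core shared by these two compounds, leaves the number within the scatter. No measured evidence offers an explanation for this result. On these data alone, whether a still longer chain, a branched chain, or an amine or carboxylic acid at the chain end would move the number beyond the scatter remains open.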